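Fluoro for methyl on the benzyl of compound 2

This account rests on a few compounds, and the source may have more. Where it says the series, first, only, none or still open, it means among the compounds named here.

Compound 2 `Cc1ccc(CN2C(=O)/C(=N\NC(=S)Nc3ccc(Cl)cc3)c3cc(Cl)ccc32)cc1` gives 9800 nM in a functional assay on L1210 cells (Mus musculus), with a stated time of 48 h (a higher number here means a weaker inhibitor, a lower number a stronger inhibitor), the lower of the two numbers in hand. Compound 1 `Cc1ccc(NC(=S)N/N=C2\C(=O)Nc3cc(Cl)c(F)cc32)cc1` gives 166000 nM in this assay, a gap beyond the scatter. Compound 3 `O=C1/C(=N\NC(=S)Nc2ccc(Cl)cc2)c2cc(Cl)ccc2N1Cc1ccc(F)cc1` differs from compound 2 by fluoro in place of methyl on an aromatic carbon. Among the compounds with values here, no measured pair shows this exchange, so no step size is known for it. The step of a 1.0-fold higher number from compound 2 to compound 3 (0.01 log units; within the scatter) is expected to be none beyond the scatter, in either direction. Compound 3 is therefore estimated at 10000 nM, with a range from 4000 nM to 25000 nM.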

Compound 3, half-maximal inhibitory concentration: 103000 nM
The estimate for compound 3 lay 10-fold (1.01 log units) below the measured number, and the stated range ends below it.
By their numbers in this assay, from the lowest: compound 2; then compounds 3 and 1 (each within the scatter of the next).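

In this assay, the para position of the benzyl group responds strongly to a single-atom exchange: 4-fluorobenzyl in place of 4-methylbenzyl gives an 11-fold higher number from compound 2 to compound 3 (1.02 log units; beyond the scatter) on an otherwise unchanged structure. This is the only step in the series that isolates one place, so the position is shown to matter, though only through this pair. Nothing available accounts for the size of the step.

Going by these compounds, whether methyl itself is favoured or fluoro is disfavoured stays open, as an unsubstituted benzyl, a methoxy or a chloro at this position would be needed to separate the two. On these data alone, the step's size on other cores, including that of compound 1, also remains unknown.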